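A Methyl Added Where Three Compounds Already Sit Silent

The source may report more compounds than this note shows. Statements on the series, on what has been measured and on what is new or still open speak of the compounds shown alone.

Compound 1 `CS(=O)(=O)OC(c1ccccc1)c1cc2ccccc2o1` — in a functional assay on MCF7 cells (Homo sapiens) for inhibition, read by MTT assay, with a stated time of 48 h (a higher number here means a weaker inhibitor, a lower number a stronger inhibitor), compound 1 gives a limit of > 40000 nM.
Compound 2 `c1ccc(C(c2cc3ccccc3o2)n2ccnc2)cc1` — in this assay compound 2 gives a limit of > 40000 nM.
Compound 3 `Cc1nccn1C(c1ccccc1)c1cc2ccccc2o1` — in this assay compound 3 gives a limit of > 40000 nM.

Compound 3 therefore stands at the upper edge of what this assay can report, sharing the limit of > 40000 nM in this assay, at which 3 of the 3 values shown sit, with both other compounds. Compound 4 `CCc1nccn1C(c1ccccc1)c1cc2ccccc2o1` carries one change: methyl in place of hydrogen on a saturated chain carbon bound to an aromatic carbon. The measured steps a step that the two limits leave unreadable from compound 1 to compound 2, a step that the two limits leave unreadable from compound 1 to compound 3 and a step that the two limits leave unreadable from compound 2 to compound 3 are all hidden behind the same limit, so none tells how a change of this kind moves this assay. No readable step is expected from compound 3 to compound 4, and compound 4 is expected to remain at or beyond the limit, a step that the limit leaves unreadable from compound 3 to compound 4. Compound 4 is estimated at 60000 nM, within 20000 nM to 200000 nM.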

Compound 4, half-maximal inhibitory concentration: > 40000 nM
Compound 4: a limit, no number; the forecaster's own chance of this, stated with the estimate: 85%; the middle value does not contradict the limit.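

Compound 4 also gives only a limit in this assay, so no step from compound 1, compound 2 or compound 3 to compound 4 can be read, and all four compounds share: the limit of > 40000 nM in this assay, at which 4 of the 4 values shown sit.

These compounds leave open whether any change to the shared core would give a readable number in this assay.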